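A Second Chloro Added to Compound 1

The source may report more compounds than this note shows. Statements on the series, on what has been measured and on what is new or still open speak of the compounds shown alone.

Among the compounds with values here, compound 1 `O=C(Nc1nc2ccccc2[nH]1)c1cccc(Cl)c1` gives 29000 nM in an assay on BV-2 cells for positive allosteric modulation of metabotropic glutamate receptor 5 (Mus musculus), read by Griess assay, with stated times of 1 h and 24 h (on this read-out lower numbers stand for stronger inhibition and higher numbers for weaker inhibition), the highest of the three numbers measured so far. Compound 2 `O=C(Nc1nc2ccccc2[nH]1)c1cc(Cl)ccc1Cl` gives 12000 nM in this assay, and compound 3 `O=C(Nc1nc2ccccc2[nH]1)c1ccc(Cl)c(Cl)c1` gives 9800 nM in this assay. Each of these carries one more chloro than compound 1, and both steps point the same way: a 2.4-fold lower number from compound 1 to compound 2 (0.38 log units; beyond the scatter) and a 3.0-fold lower number from compound 1 to compound 3 (0.47 log units; beyond the scatter). Compound 4 `O=C(Nc1nc2ccccc2[nH]1)c1cc(Cl)cc(Cl)c1` has not yet been measured. It differs from compound 1 by chloro in place of hydrogen on an aromatic carbon. Within the data shown here, the two measured steps each add a single chloro to the same ring of compound 1 and each lowered the number by a modest amount beyond the scatter, so a step of similar size and direction is expected here, although no measured step places the added chloro at this particular spot. For compound 4 the expected step is a 2.6-fold lower number from compound 1 to compound 4 (0.42 log units; beyond the scatter). Compound 4 is accordingly estimated at 11000 nM in this assay, with a range from 5000 nM to 25000 nM.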

Compound 4, half-maximal inhibitory concentration: 6400 nM
Estimate against measurement, compound 4: 1.7-fold (0.24 log units) above; low and high end bracket the measured number.
By their numbers in this assay, from the lowest: compounds 4, 3 and 2 (each within the scatter of the next); then compound 1.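

Chloro in place of hydrogen on the aromatic carbon meta to a chloro group and meta to a large group gives a 4.5-fold lower number from compound 1 to compound 4 (0.66 log units; beyond the scatter) in this assay, so this spot, which no earlier step covered, responds in the same direction as the other two. All three additions of a second chloro to compound 1 now lower the number, none goes against this, and compounds 4, 3 and 2 lie within the scatter of one another, so these numbers do not separate the three placements. Nothing shown accounts for the size of this step.

Whether the step is particular to chloro stays open, as another group at this spot, such as methoxy, trifluoromethyl or an amine, is not among the compounds shown. Also open, from the compounds shown here alone, is what a third chloro on the same ring would do.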